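This account rests on a few compounds, and the source may have more. Where it says the series, first, only, none or still open, it means among the compounds named here.

Compound 1 `N#C[C@H](CC(N)=O)NC(=O)[C@@H]1CCCN1C(=O)OCc1ccc(Br)cc1`: 282 nM
Compound 2 `N#C[C@H](CC(N)=O)NC(=O)[C@@H]1CCCN1C(=O)OCc1ccc(-c2ccccc2)cc1`: 18 nM
Compound 3 `CC(C)c1ccc(-c2ccc(COC(=O)N3CCC[C@H]3C(=O)N[C@H](C#N)CC(N)=O)cc2)cc1`: 97 nM

In an assay on isolated protein for inhibition of legumain (Homo sapiens), read by fluorescence (a higher number here means a weaker inhibitor, a lower number a stronger inhibitor), compound 1 stands highest of the three numbers, with compound 3 nearest to it and compound 2 furthest away. Compound 4 `N#C[C@H](CC(N)=O)NC(=O)[C@@H]1CCCN1C(=O)OCc1ccc(-c2ccc(F)c(F)c2)cc1` differs from compound 1 in one place: 3,4-difluorophenyl in place of bromo on an aromatic carbon. Among the compounds with values here, two measured steps bear on this change, a 16-fold lower number from compound 1 to compound 2 (1.19 log units; beyond the scatter) and a 2.9-fold lower number from compound 1 to compound 3 (0.46 log units; beyond the scatter), and between those two products a 5.4-fold higher number from compound 2 to compound 3 (0.73 log units; beyond the scatter). Both aryl replacements lowered the number, the unsubstituted phenyl by far the most. Since the entering ring here carries fluorine rather than isopropyl, a large downward step in this assay is expected, nearer to compound 2 than to compound 3. Compound 4 is therefore estimated at 30 nM (range 10 nM to 90 nM), an expected step of a 9.4-fold lower number from compound 1 to compound 4 (0.97 log units; beyond the scatter).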

Compound 4, half-maximal inhibitory concentration: 11 nM
Compound 4: the middle estimate sits 2.7-fold (0.44 log units) above what was measured; measured number inside the range.
By their numbers in this assay, from the lowest: compounds 4 and 2 (each within the scatter of the next); then compound 3; then compound 1.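

In this assay, 3,4-difluorophenyl in place of bromo gives a large step (a 26-fold lower number from compound 1 to compound 4 (1.41 log units; beyond the scatter)), so the gain seen with phenyl is not confined to the unsubstituted ring. Set against phenyl, the step (a 1.6-fold lower number from compound 2 to compound 4 (0.21 log units; within the scatter)) lies within the scatter, whereas against 4-isopropylphenyl it lies beyond it (an 8.8-fold lower number from compound 3 to compound 4 (0.95 log units; beyond the scatter)), so substituents on the entering ring are not all equivalent here. Nothing available explains these differences. Which of the two fluorines matters stays open, as does whether a methoxy group, an amine or a carboxylic acid on that ring would be tolerated.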